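Swapping Amino for Hydroxy on a Shared Urea Core

The compounds below may be only part of what the source reports. "The series", "measured", "known", "first", "only" and "open" are said of these compounds alone.

Measured so far:
compound 1 `Cc1cc(NC(=O)Nc2ccc(C)c(Cl)c2)c2ccccc2n1` — 262 10^-6 cm/s
compound 2 `Cc1cc(NC(=O)Nc2ccccc2C(F)(F)F)c2ccccc2n1` — 945 10^-6 cm/s
compound 3 `Cc1cc(NC(=O)Nc2ccc(N)cc2)c2ccccc2n1` — 530 10^-6 cm/s

These three were tested in an ADME assay for permeability, using PAMPA, at pH 7.4; a lower number here means that the compound crosses the layer more slowly, a higher number that the compound crosses the layer faster. Compound 3 sits second highest of the three: compound 2 gives a number within the scatter of it, while compound 1 gives a number that is lower beyond the scatter. Compound 4 `Cc1cc(NC(=O)Nc2ccc(O)cc2)c2ccccc2n1` is not yet measured. It differs from compound 3 in one place: hydroxy in place of amino on an aromatic carbon. One donor and one acceptor leave, and one donor and one acceptor enter, so the count of polar groups stays the same. Among the measured compounds shown here, no step of this kind has been measured here, so a small step is expected, if any beyond the scatter, with no clear direction. For compound 4 the expected value is 550 10^-6 cm/s, with a range from 250 10^-6 cm/s to 1100 10^-6 cm/s, an expected step of a 1.0-fold higher number from compound 3 to compound 4 (0.02 log units; within the scatter).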

Compound 4, apparent permeability: 3 10^-6 cm/s
For compound 4 the middle estimate is 180-fold (2.26 log units) above the measured one, outside the stated range (below it).
By their numbers in this assay, from the lowest: compound 4; then compound 1; then compounds 3 and 2 (each within the scatter of the next).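

Swapping amino for hydroxy in this assay gives a 180-fold lower number from compound 3 to compound 4 (2.25 log units; beyond the scatter) and so shows that this para position can matter greatly, even for a change of one heavy atom. The hydrogen-bond donor and acceptor counts stay the same across the change, so those counts alone do not capture the difference between these two compounds.

On these data alone, whether a methoxy group or a carboxylic acid at this position would give a number nearer compound 3 or compound 4 remains open. No measurement shown here gives a reason for the drop.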